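The compounds below may be only part of what the source reports. "The series", "measured", "known", "first", "only" and "open" are said of these compounds alone.

In a functional assay on COS-7 cells (Chlorocebus aethiops) for inhibition, read by MTT assay (on this read-out lower numbers stand for stronger inhibition and higher numbers for weaker inhibition), compound 1 `O=C1Nc2ccc(Br)cc2/C1=N/NC(=S)N/N=C/c1ccc(-c2ccccc2)cc1` reaches only the limit of the measurement, > 50000 nM. Compound 2 `Cc1ccc(O)c(/C=N/NC(=S)N/N=C2\C(=O)Nc3ccc(Br)cc32)c1` likewise stops at the limit in this assay, with > 50000 nM. Compound 3 `O=C1Nc2ccc(Br)cc2/C1=N/NC(=S)N/N=C/c1ccc(Br)cc1` gives a true number in this assay, 5180 nM. Two measured steps lead to compound 3: an at least 9.6-fold lower number from compound 1 to compound 3 (0.98 log units; beyond the scatter), and an at least 9.6-fold lower number from compound 2 to compound 3 (0.98 log units; beyond the scatter). Both exchanges concern the group hanging from the carbon with a double bond to nitrogen; neither touches the bromo on the shared core.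

Compound 4 `Cc1ccc2c(c1)/C(=N/NC(=S)N/N=C/c1ccc(-c3ccccc3)cc1)C(=O)N2` keeps the phenyl end of compound 1 and differs in one place only: methyl in place of bromo on an aromatic carbon. Among the measured compounds shown here, no measured step reports this particular exchange, so there is nothing that would predict a move out of the scatter. Compound 1 sits at the same point as compound 2, namely (the limit of > 50000 nM in this assay, at which 2 of the 3 values shown sit). Compound 4 is therefore expected to remain at that limit, with an estimate of 80000 nM and a range from 20000 nM to 300000 nM. The expected step is a step that the limit leaves unreadable from compound 1 to compound 4, within the scatter.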

Compound 4, half-maximal inhibitory concentration: > 50000 nM
Compound 4: only a limit was reported; the forecaster's own chance of this, stated with the estimate: 75%; the middle value lies beyond the limit too.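

Among the compounds shown here, compound 4 gives only a limit in this assay, > 50000 nM, and compound 1 also gives only a limit, so no step between them can be read. The compounds shown leave open whether methyl in place of bromo changes the inhibition at all, with most values resting at one point: the limit of > 50000 nM in this assay, at which 3 of the 4 values shown sit.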